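Removing a Methyl from a Thiosemicarbazone's Pyridine Ring

A few compounds are considered here, and "the series" means these few. Any claim that something is new, unique, unknown or untested is made for them only; others in the source may bear on it.

Measured so far in a functional assay on A-375 cells (Homo sapiens) for cytotoxicity, read by MTT assay, with a stated time of 72 h, tested at 10 uM; a lower number here means less inhibition of growth, a higher number more inhibition of growth at the concentration tested:
compound 1, `N/C(=N\NC(=S)N1CCCCCC1)c1ccccn1`, gives 86.5%
compound 2, `N/C(=N\NC(=S)N1CCCC1)c1ccc(F)cn1`, gives 82.3%
compound 3, `Cc1cccc(/C(N)=N/NC(=S)N2CCSCC2)n1`, gives 62.6%

Compound 3 stands lowest of the three numbers. Its nearest neighbour is compound 2, whose number sits higher by a margin beyond the scatter, and compound 1 lies further above it, again beyond the scatter. The three compounds differ in more than one place, so no single structural step among them can be read as the reason for these gaps.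

The unmeasured compound 4, `N/C(=N\NC(=S)N1CCSCC1)c1ccccn1`, is reached from compound 3 by one change: hydrogen in place of methyl on an aromatic carbon, next to the ring nitrogen and meta to a large group. The two compounds with an unmethylated pyridine ring, compound 1 and compound 2, both give high numbers in this assay, though each also carries a different amine, so the comparison is indirect.

Given this, compound 4 is expected to move upward from compound 3 by a number 12.4 percentage points higher from compound 3 to compound 4 (beyond the scatter), a step judged to lie beyond the scatter but not certain to. Compound 4 is estimated at 75%, within a range of 56% to 92%.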

Compound 4, percent growth inhibition at one concentration: 83.9%
Beside the measured number, compound 4's estimate is 8.9 percentage points below it, within the range that was stated.
By their numbers in this assay, from the lowest: compound 3; then compounds 2, 4 and 1 (each within the scatter of the next).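

In this assay, putting hydrogen in place of methyl on this aromatic carbon, next to the ring nitrogen and meta to a large group, gives a number 21.3 percentage points higher from compound 3 to compound 4 (beyond the scatter), a modest step. Going by these compounds alone, this is the first pair that differs in one place only, so the link between the unmethylated pyridine ring and the higher number, previously seen only across compounds with different amines, now rests on a direct comparison with the amine unchanged. The data show that a single methyl at this position goes with lower growth inhibition at the concentration tested, but no measurement at hand says why the number moves.

The compounds shown leave open whether the same step would appear with a different amine, such as the one carried by compound 1, since this comparison comes from a single pair. Going by these compounds, they also leave open how an ethyl, a methoxy or an amino group on this same carbon would compare with methyl and hydrogen, so it remains unknown whether the drop is particular to methyl or extends to other groups at this position.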